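A few compounds are considered here, and "the series" means these few. Any claim that something is new, unique, unknown or untested is made for them only; others in the source may bear on it.

Of the compounds shown here, three that share one core have been measured in a functional assay on T47D cells (Homo sapiens) for cytotoxicity, read by sulforhodamine B assay, with a stated time of 48 h; a higher number here means a weaker inhibitor of growth, a lower number a stronger inhibitor of growth. Compound 1 `ClCc1ccccc1Cn1cnc2c(Cl)ncnc21` gives 61700 nM in this assay. Compound 2 `ClCc1ccc(Cn2cnc3nc(Cl)nc(Cl)c32)cc1` gives 46800 nM in this assay. Compound 3 `ClCc1ccccc1Cn1cnc2ncnc(Cl)c21` gives 4260 nM in this assay, the lowest of the three numbers; the numbers of compound 2 and of compound 1 both lie beyond the scatter from it. No two of the three compounds differ in only one place, so no single step can be read from them. Compound 4 `ClCc1ccccc1Cn1cnc2nc(Cl)nc(Cl)c21` has not yet been measured in this assay. It differs from compound 3 by chloro in place of hydrogen on an aromatic carbon. Compound 2 also carries two chloro groups on the core, but it differs from compound 3 in a second place as well, so its number alone does not show what this change does. Lacking a measured step to rest on, the step from compound 3 to compound 4 is expected to be small, in either direction, or within the scatter, a 1.4-fold higher number from compound 3 to compound 4 (0.15 log units; within the scatter). Compound 4 is therefore estimated to give 6000 nM in this assay, with a range from 1500 nM to 25000 nM.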

Compound 4, concentration for total growth inhibition: 5240 nM
Compound 4: middle estimate off by 1.1-fold (0.06 log units), on the high side, and the stated range covers the measured number.
By their numbers in this assay, from the lowest: compounds 3 and 4 (each within the scatter of the next); then compounds 2 and 1 (each within the scatter of the next).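

In this assay, going by these compounds alone, chloro in place of hydrogen on the aromatic carbon between two ring nitrogen atoms gives a 1.2-fold higher number from compound 3 to compound 4 (0.09 log units; within the scatter), the first single change that can be read in this set. This step lies within the scatter, so at this position chloro and hydrogen cannot be told apart in this read-out, something compound 2 could not show because it differs from compound 3 in a second place as well. Nothing measured here offers an explanation for this result.

Going by these compounds, whether an amine, a methoxy group or a longer chain at this carbon would also stay within the scatter of compound 3 remains open. On these data alone, it is also open whether the same change would give so small a step elsewhere on the shared core.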